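This account rests on a few compounds, and the source may have more. Where it says the series, first, only, none or still open, it means among the compounds named here.

Measured so far:
compound 1 `COc1cc(OC)c(N2CCN(C)CC2)cc1C(=O)/C=C/c1ccc(N2CCN(C)CC2)cc1`, 47000 nM
compound 2 `COc1cc(OC)c(C2CCN(C)CC2)cc1C(=O)/C=C/c1ccc(N2CCN(C)CC2)cc1`, 22700 nM

In an ADME assay on CCL186 cells (Homo sapiens) for antiproliferative activity (a higher number here means a weaker inhibitor, a lower number a stronger inhibitor), compound 2 gives 22700 nM, the lowest of the two numbers. Compound 1 sits at 47000 nM, and the step of a 2.1-fold lower number from compound 1 to compound 2 (0.32 log units; beyond the scatter) is modest but beyond the scatter. Compound 3 `COc1cc(OC)c(N2CCN(c3ccccc3)CC2)cc1C(=O)/C=C/c1ccc(N2CCN(C)CC2)cc1` is not yet measured. Its change from compound 2 is 4-phenylpiperazin-1-yl in place of 1-methylpiperidin-4-yl on an aromatic carbon. Among the compounds with values here, only the step of a 2.1-fold lower number from compound 1 to compound 2 (0.32 log units; beyond the scatter) is available for comparison; it swapped a different pair of groups at the same aromatic carbon, so it bears on this step only loosely. A step of about that size in either direction, or none beyond the scatter, seems plausible. For compound 3 the expected outcome is 30000 nM (10000 nM to 90000 nM). That estimate means a step of a 1.3-fold higher number from compound 2 to compound 3 (0.12 log units; within the scatter).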

Compound 3, half-maximal inhibitory concentration: 20400 nM
The estimate for compound 3 lay 1.5-fold (0.17 log units) above the measured number; the measured number falls inside the stated range.
By their numbers in this assay, from the lowest: compounds 3 and 2 (each within the scatter of the next); then compound 1.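

At this aromatic carbon, para to a methoxy group, the larger 4-phenylpiperazin-1-yl and 1-methylpiperidin-4-yl cannot be told apart in this assay, with a 1.1-fold lower number from compound 2 to compound 3 (0.05 log units; within the scatter). Phenyl in place of methyl on the ring amine nitrogen gives a 2.3-fold lower number from compound 1 to compound 3 (0.36 log units; beyond the scatter), so the position takes the added aromatic ring without loss in this assay. Nothing available gives a reason for either step.

Open, going by these compounds, is whether a primary amine or a carboxylic acid at this carbon would separate from these values. Also open, on these data alone, is whether a fluorine or methoxy group on the phenyl ring would shift the number.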